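Shortening the group on the ring nitrogen of compound 3

A few compounds are considered here, and "the series" means these few. Any claim that something is new, unique, unknown or untested is made for them only; others in the source may bear on it.

Three compounds share one core and differ only in the part attached to it. Compound 1 `Cc1nn(C(C)(C)C)c2nc(C(C)C)c(/C=C/[C@@H](O)C[C@@H](O)CC(=O)O)c(-c3ccc(F)cc3)c12` gives 86% in an in vivo functional assay on the whole organism for inhibition of 3-hydroxy-3-methylglutaryl-coenzyme A reductase (Rattus norvegicus), at a dose of 2 mg/kg by the oral route; on this read-out lower numbers stand for a weaker effect and higher numbers for a stronger effect at the one dose given. Compound 2 `CCc1c(C)sc2nc(C(C)C)c(/C=C/[C@@H](O)C[C@@H](O)CC(=O)O)c(-c3ccc(F)cc3)c12` gives 20.8% in this assay. Compound 3 `Cc1nn(Cc2ccccc2)c2nc(C(C)C)c(/C=C/[C@@H](O)C[C@@H](O)CC(=O)O)c(-c3ccc(F)cc3)c12` gives 45.1% in this assay, which puts it second highest of the three numbers, clearly separated from both others.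

Compound 4 `Cc1nn(C)c2nc(C(C)C)c(/C=C/[C@@H](O)C[C@@H](O)CC(=O)O)c(-c3ccc(F)cc3)c12` is not yet measured. The change from compound 3 to compound 4 is hydrogen in place of phenyl on a saturated chain carbon bound to an aromatic nitrogen, so the group on the aromatic nitrogen shrinks from benzyl to methyl.

Within the data shown here, no measured step changes a benzyl to a methyl here. Among the measured compounds shown here, the one step that touches the same position is a number 40.9 percentage points lower from compound 1 to compound 3 (beyond the scatter), and it shows that altering the group on that nitrogen can move the read-out a great deal. That step does not tell in which direction a further shortening would go, so a large step either way is possible, and the estimate sits close to where compound 3 already stands with a wide range.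

Compound 4 is therefore expected to give about 45% in this assay, most likely between 15% and 75%. The expected step is a number 0.1 percentage points lower from compound 3 to compound 4 (within the scatter).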

Compound 4, a percentage reported as inhibition, in the whole organism at one dose (the size of the read-out at that dose, not a potency): 48.1%
Estimate against measurement, compound 4: 3.1 percentage points below, within the range that was stated.
By their numbers in this assay, from the lowest: compound 2; then compounds 3 and 4 (each within the scatter of the next); then compound 1.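

In this assay, taking the phenyl off the benzyl group so that a methyl remains on the aromatic nitrogen gives a number 3 percentage points higher from compound 3 to compound 4 (within the scatter), so at this one dose the read-out does not separate a group carrying a phenyl ring from a group with none. Replacing tert-butyl with methyl gives a number 37.9 percentage points lower from compound 1 to compound 4 (beyond the scatter), and this is the second large step away from compound 1 at this position, so of the three groups seen on this nitrogen, only tert-butyl goes with the high read-out. Nothing measured here bears on the cause of this pattern.

The compounds shown leave open whether the high read-out belongs to tert-butyl alone or would also appear with another branched group on this nitrogen, such as isopropyl or cyclobutyl. They also leave open how a longer chain, or a chain ending in an amine or a carboxylic acid, would behave there, and a single oral dose in the whole organism cannot show how far any of these numbers reflect the enzyme itself.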